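The compounds below may be only part of what the source reports. "The series", "measured", "known", "first", "only" and "open" are said of these compounds alone.

Measured compounds in a functional assay on RAW264.7 cells (Mus musculus) for inhibition, read by Griess assay, with stated times of 2 h and 24 h; a lower number here means a stronger inhibitor, a higher number a weaker inhibitor:
compound 1, `COc1ccc([C@@H]2CC(=O)c3c(O)cc(OCc4cn(Cc5ccc(C(F)(F)F)cc5)nn4)cc3O2)cc1O`, 17700 nM;
compound 2, `COc1ccc([C@@H]2CC(=O)c3c(O)cc(OCc4cn(Cc5ccc(C)cc5)nn4)cc3O2)cc1O`, 16800 nM.

Compound 1 stands highest of the two numbers in this assay; its nearest neighbour is compound 2, and the step of a 1.1-fold lower number from compound 1 to compound 2 (0.02 log units; within the scatter) lies within the scatter, so the two compounds are not separated by the data. Compound 3, `CCCCn1cc(COc2cc(O)c3c(c2)O[C@H](c2ccc(OC)c(O)c2)CC3=O)nn1`, has not yet been measured in this assay. It differs from compound 1 in one place: propyl in place of 4-(trifluoromethyl)phenyl on a saturated chain carbon bound to an aromatic nitrogen. The only measured step, a 1.1-fold lower number from compound 1 to compound 2 (0.02 log units; within the scatter), swaps one group on the aromatic ring and leaves the ring itself in place; it gives no guide to removing the ring and putting a chain in its place, so no shown step bears directly on this change. With only a step of no size to go by, compound 3 is expected to stay close to compound 1, and the expected step of a 1.1-fold higher number from compound 1 to compound 3 (0.05 log units; within the scatter) should lie within the scatter. Compound 3 is therefore estimated at 20000 nM, with a range from 7000 nM to 60000 nM.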

Compound 3, half-maximal inhibitory concentration: 13900 nM
Compound 3: middle estimate off by 1.4-fold (0.16 log units), on the high side; low and high end bracket the measured number.
By their numbers in this assay, from the lowest: compounds 3, 2 and 1 (each within the scatter of the next).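

In this assay, removing the aromatic ring at this place, on a saturated chain carbon bound to an aromatic nitrogen, and putting propyl there gives a 1.3-fold lower number from compound 1 to compound 3 (0.10 log units; within the scatter), and the same change made from 4-methylphenyl gives a 1.2-fold lower number from compound 2 to compound 3 (0.08 log units; within the scatter). Among the compounds shown here, the earlier pair showed only that a swap of one group on that ring did not separate the compounds; these steps show that replacing the whole ring with a chain does not separate them either, so the data give no sign that the ring is required at this place in this assay. No supporting evidence bears on this result.

From the compounds shown here alone, what remains open is whether anything at this place can separate from these three compounds, for instance an amine, a carboxylic acid or a chain longer than butyl. The compounds shown also leave open whether changes to the shared core would matter more than changes here.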